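Amine side-chain swap on a shared core: working notes

A few compounds are considered here, and "the series" means these few. Any claim that something is new, unique, unknown or untested is made for them only; others in the source may bear on it.

Measured compounds:
compound 1 `CCN(CC)CCn1c(N)c(-c2nc3ccccc3n2C)c2nc(C#N)c(C#N)nc21`: > 50000 nM
compound 2 `CN(C)CCCn1c(N)c(-c2nc3ccccc3n2C)c2nc(C#N)c(C#N)nc21`: 3670 nM
compound 3 `CCN(CC)CCCn1c(N)c(-c2nc3cc(Cl)ccc3[nH]2)c2nc(C#N)c(C#N)nc21`: 23200 nM

In a functional assay on cells (Homo sapiens) for antiproliferative activity, read by MTT assay, with a stated time of 48 h (on this read-out higher numbers stand for weaker inhibition and lower numbers for stronger inhibition), compound 2 gives 3670 nM and compound 3 gives 23200 nM. Compound 1 gives only a limit of the assay, > 50000 nM (the limit of > 50000 nM in this assay, at which 1 of the 3 values shown sits). The change (dimethylamino)methyl in place of diethylamino on a saturated chain carbon, two bonds along the chain from an aromatic nitrogen produced an at least 13-fold lower number from compound 1 to compound 2 (1.13 log units; beyond the scatter).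

Compound 4 `CN(C)CCCCn1c(N)c(-c2nc3cc(Cl)ccc3[nH]2)c2nc(C#N)c(C#N)nc21` differs from compound 3 by (dimethylamino)methyl in place of diethylamino on a saturated chain carbon, three bonds along the chain from an aromatic nitrogen. The change is the same kind as that between compound 1 and compound 2, but it sits three bonds along the chain from the aromatic nitrogen rather than two. The cores of compound 1 and compound 3 also differ, and that difference is not broken down here.

Because an at least 13-fold lower number from compound 1 to compound 2 (1.13 log units; beyond the scatter) went in this direction, a step of a 4.6-fold lower number from compound 3 to compound 4 (0.67 log units; beyond the scatter) is expected for compound 4, smaller since the earlier one started from a limit. Compound 4 is estimated at 5000 nM (1500 nM to 20000 nM).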

Compound 4, half-maximal inhibitory concentration: 3280 nM
Estimate against measurement, compound 4: 1.5-fold (0.18 log units) above; the range from low to high includes it.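

In this assay the change from diethylamino to (dimethylamino)methyl gives a 7.1-fold lower number from compound 3 to compound 4 (0.85 log units; beyond the scatter) and so runs in the same direction on both cores shown. Set side by side, the two steps read: the same change on two cores in this assay, an at least 13-fold lower number (1.13 log units; beyond the scatter) from compound 1 to compound 2 and a 7.1-fold lower number (0.85 log units; beyond the scatter) from compound 3 to compound 4; the limit leaves it open whether they differ. Among these compounds, with only two pairs, this shows no general rule, and the change sits two bonds along the chain from an aromatic nitrogen in one pair and three bonds along it in the other.

Still open, on these data alone, is whether the direction holds on a third core or with a cyclic amine such as morpholine at the chain end. A 4-(diethylamino)butyl chain on the core of compound 3 would help separate the contribution of the chain from that of the amine.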